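Removing trifluoromethyl from the terminal ether in a benzimidazole series

A few compounds are considered here, and "the series" means these few. Any claim that something is new, unique, unknown or untested is made for them only; others in the source may bear on it.

The study uses a functional assay on KB cells (Homo sapiens) for inhibition, read by sulforhodamine B assay (on this read-out lower numbers stand for stronger inhibition of growth and higher numbers for weaker inhibition of growth), to compare four terphenyl-benzimidazoles. Compound 1 `FC(F)(F)Oc1ccc(-c2ccc(-c3ccc(-c4nc5ccccc5[nH]4)cc3)cc2)cc1` gives 39100 nM in this assay. Compound 2 `Oc1ccc(-c2ccc(-c3ccc(-c4nc5ccccc5[nH]4)cc3)cc2)cc1` carries a (hydrogen in place of trifluoromethyl on an oxygen on an aromatic ring), and the result in this assay is 41000 nM, so the step is a 1.0-fold higher number from compound 1 to compound 2 (0.02 log units; within the scatter). Compound 3 `Oc1cccc2[nH]c(-c3ccc(-c4ccc(-c5ccc(OC(F)(F)F)cc5)cc4)cc3)nc12` differs from compound 1 by a (hydroxy in place of hydrogen on an aromatic carbon); in this assay compound 3 gives 3310 nM, and the step is a 12-fold lower number from compound 1 to compound 3 (1.07 log units; beyond the scatter).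

Compound 4 `Oc1ccc(-c2ccc(-c3ccc(-c4nc5c(O)cccc5[nH]4)cc3)cc2)cc1` has not been measured. It differs from compound 3 by a (hydrogen in place of trifluoromethyl on an oxygen on an aromatic ring), which is the same change as that between compound 1 and compound 2, made at the same place and on a core that differs from theirs by the hydroxy on the benzimidazole just described.

Among the measured compounds shown here, the only precedent for this change, the step of a 1.0-fold higher number from compound 1 to compound 2 (0.02 log units; within the scatter), lies within the scatter, so compound 4 is expected to show a step of about a 1.1-fold higher number from compound 3 to compound 4 (0.02 log units; within the scatter) in this assay. On that basis compound 4 is estimated at 3500 nM, with a likely range from 1500 nM to 8500 nM.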

Compound 4, concentration for 50% growth inhibition: 3190 nM
Estimate against measurement, compound 4: 1.1-fold (0.04 log units) above; the range from low to high includes it.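

In this assay, removing trifluoromethyl from the terminal ether on the hydroxy-bearing core changes nothing beyond the scatter, with a 1.0-fold lower number from compound 3 to compound 4 (0.02 log units; within the scatter), and this agrees with the earlier step on the core of compound 1: the same change on two cores in this assay, a 1.0-fold higher number (0.02 log units; within the scatter) from compound 1 to compound 2 and a 1.0-fold lower number (0.02 log units; within the scatter) from compound 3 to compound 4, 1.1-fold (0.04 log units) apart, within the scatter of two such steps. The hydroxy in place of hydrogen on an aromatic carbon also gives a large step when the terminal group is 4-hydroxyphenyl, with a 13-fold lower number from compound 2 to compound 4 (1.11 log units; beyond the scatter), and this matches the step seen with 4-(trifluoromethoxy)phenyl: the same change on two cores in this assay, a 12-fold lower number (1.07 log units; beyond the scatter) from compound 1 to compound 3 and a 13-fold lower number (1.11 log units; beyond the scatter) from compound 2 to compound 4, 1.1-fold (0.04 log units) apart, within the scatter of two such steps. Each change therefore carries over between the two cores shown here, but this rests on four compounds in a single assay and does not show that it would hold on any other core, or why the numbers behave this way.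

The compounds shown leave open whether a methyl or a longer chain on the terminal oxygen would give the same result. They also leave open whether an amine or a carboxylic acid in place of the new hydroxy would keep the large step.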